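A few compounds are considered here, and "the series" means these few. Any claim that something is new, unique, unknown or untested is made for them only; others in the source may bear on it.

Compound 1 `Cc1n[nH]c2ccc(-c3nc4cnc(N5CCN(C)CC5)cn4c3Nc3ccccc3F)cc12` is the single reference point of the series: in a functional assay on CWR22R cells (Homo sapiens) for inhibition, with a stated time of 120 h, tested at 10 uM (on this read-out lower numbers stand for less inhibition and higher numbers for more inhibition at the one concentration tested (going by the name of the read-out)), compound 1 gives 0%. Compound 2 `Cc1n[nH]c2ccc(-c3nc4cnc(N5CCN(C)CC5)cn4c3Nc3ccc(F)cc3)cc12` is a fluorine-bearing analogue, and in this assay compound 2 returns "not determined" (no result reported). Compound 3 `Cc1n[nH]c2ccc(-c3nc4cnc(N5CCN(C)CC5)cn4c3Nc3ccccc3)cc12`, the plain anilino member, likewise carries no number in this assay, where compound 3 reads "not determined" (no result reported). Compound 3 therefore stands nowhere on the numbers shown; the only measured member is compound 1, and that sits at zero.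

Compound 4 `Cc1n[nH]c2ccc(-c3nc4cnc(N5CCN(C)CC5)cn4c3Nc3ccc(F)c(Cl)c3)cc12` differs from compound 3 by 3-chloro-4-fluorophenyl in place of phenyl on a nitrogen on an aromatic ring. Going by the values given here, no measured pair isolates this change, so its size in this assay cannot be read from the data; with compound 1 at 0% the expectation is a step of no more than the usual scatter, in either direction, most probably none beyond it. Compound 4 is accordingly expected to give 5% in this assay, with the estimate spanning 0% to 25%.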

Compound 4, a percentage reported as inhibition, at one concentration (the size of the read-out at that concentration, not a potency): 0.82%
Estimate against measurement, compound 4: 4.2 percentage points above, within the range that was stated.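

In this assay, going by these compounds alone, 3-chloro-4-fluorophenyl in place of 2-fluorophenyl on a nitrogen on an aromatic ring gives a number 0.8 percentage points higher from compound 1 to compound 4 (within the scatter), the first step that can be read at this position. At the one concentration tested, the read-out therefore does not separate these two halogen-bearing phenyl groups, and neither compound stands clear of the other. No measured property bears on this result.

The steps involving compound 2 and compound 3 cannot be read, so the plain phenyl and 4-fluorophenyl groups remain unplaced against these two. Also open, from the compounds shown here alone, is whether a different group on this nitrogen, such as cyclohexyl, pyridyl or a phenyl ring carrying a carboxylic acid, would move the read-out beyond the usual scatter in this assay.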